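This account rests on a few compounds, and the source may have more. Where it says the series, first, only, none or still open, it means among the compounds named here.

Compound 1 `C[C@H]1N=C2C[C@H]3C[C@H](C3(C)C)[C@@]2(C)OC1=O` is the starting point here. In an ADME assay on NIH3T3 cells (Mus musculus) for antiproliferative activity, read by sulforhodamine B assay, with a stated time of 48 h (a lower number here means a stronger inhibitor, a higher number a weaker inhibitor), compound 1 gives > 1800000 nM, which is a limit of the assay rather than a number. Compound 2 `CC1(C)[C@H]2CC3=NCC(=O)O[C@]3(C)[C@@H]1C2` gives > 2000000 nM in this assay, again a limit. The step that the two limits leave unreadable from compound 1 to compound 2 therefore cannot be read, and both values shown for this set stand at a limit, so compound 1 has no firm place on a scale. Compound 3 `CC(C)(C)OC(=O)CC[C@H]1N=C2C[C@H]3C[C@H](C3(C)C)[C@@]2(C)OC1=O` differs from compound 1 by (tert-butoxycarbonyl)methyl in place of hydrogen on a saturated chain carbon bound to a saturated ring carbon. Among the compounds with values here, no measured step touches this position, and the one measured step is unreadable, so no size or direction beyond the scatter can be expected from it. Compound 3 is estimated at 3000000 nM, with a range of 800000 nM to 10000000 nM, an expected step that the limit leaves unreadable from compound 1 to compound 3.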

Compound 3, half-maximal inhibitory concentration: > 1200000 nM
Compound 3 was reported as a limit (the forecaster's own chance of this, stated with the estimate: 80%); the middle value is on the limit's open side.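

Compound 3 and compound 1 both stand at limits of this assay, so the step between them cannot be read. The compounds shown leave open whether any of them has a measurable potency in this assay.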